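The compounds below may be only part of what the source reports. "The series", "measured", "known", "first", "only" and "open" are said of these compounds alone.

For the measured compounds named here, in a functional assay on A549 cells (Homo sapiens) for antiproliferative activity, read by MTT assay, with a stated time of 72 h (on this read-out lower numbers stand for stronger inhibition and higher numbers for weaker inhibition), three compounds sharing one core have numbers so far. Compound 1 (`O=C(N/N=C/c1ccc(Br)cc1)Nc1ccc(Oc2ccnc3[nH]ccc23)c(F)c1`) gives 820 nM, compound 2 (`N#Cc1ccc(/C=N/NC(=O)Nc2ccc(Oc3ccnc4[nH]ccc34)c(F)c2)cc1`) gives 1360 nM, and compound 3 (`O=C(N/N=C/c1ccc(F)cc1Cl)Nc1ccc(Oc2ccnc3[nH]ccc23)c(F)c1`) gives 10 nM, the lowest of the three and clearly apart from both others. The unmeasured compound 4 (`O=C(N/N=C/c1ccc(O)cc1O)Nc1ccc(Oc2ccnc3[nH]ccc23)c(F)c1`) differs from compound 3 at a single place, on a carbon with a double bond to nitrogen: 2,4-dihydroxyphenyl in place of 2-chloro-4-fluorophenyl on a carbon with a double bond to nitrogen.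

Two measured steps involve a change at this same place. One is an 82-fold lower number from compound 1 to compound 3 (1.91 log units; beyond the scatter), and the other is a 140-fold lower number from compound 2 to compound 3 (2.13 log units; beyond the scatter). Both are large, and both end at the 2-chloro-4-fluorophenyl group that compound 4 gives up. The third step, a 1.7-fold higher number from compound 1 to compound 2 (0.22 log units; within the scatter), stays within the scatter. None of these steps introduces a hydroxyl group, so the data offer no direct guide to the 2,4-dihydroxyphenyl group, and three compounds support only a loose expectation. Going by the values given here, since the only other groups tried at this place sit on the higher side of those two large steps, a sizeable move upward seems more likely than no change. The expected change is a 25-fold higher number from compound 3 to compound 4 (1.40 log units; beyond the scatter), which would be beyond the scatter. For compound 4 the estimated value is 250 nM, with an expected range from 30 nM to 1800 nM.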

Compound 4, half-maximal inhibitory concentration: 5840 nM
Compound 4: the middle estimate sits 23-fold (1.37 log units) below what was measured; the whole stated range lies below it.
By their numbers in this assay, from the lowest: compound 3; then compounds 1 and 2 (each within the scatter of the next); then compound 4.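

In this assay, the 2,4-dihydroxyphenyl group brings a 580-fold higher number from compound 3 to compound 4 (2.77 log units; beyond the scatter), so the low number of compound 3 does not survive this exchange on a carbon with a double bond to nitrogen. The new group also ends above both earlier groups that were far weaker than 2-chloro-4-fluorophenyl, with a 7.1-fold higher number from compound 1 to compound 4 (0.85 log units; beyond the scatter) and a 4.3-fold higher number from compound 2 to compound 4 (0.63 log units; beyond the scatter), both modest, which shows that numbers at this place can rise past those of 4-bromophenyl and 4-cyanophenyl. The exchange keeps the count of heavy atoms and the aromatic ring while hydrogen-bond donors and acceptors go from 0 to 2, and nothing at hand explains why the number moves so far.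

As far as these compounds go, the two groups differ in both of their substituents, so it stays open whether the step belongs to one hydroxyl group or to both, and to the loss of the chlorine or of the fluorine. Also open, from the compounds shown here alone, is how methoxy groups or an amine in place of the hydroxyl groups would behave at this place.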